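Replacing One Aryl Group on a Shared Core

This account rests on a few compounds, and the source may have more. Where it says the series, first, only, none or still open, it means among the compounds named here.

compound 1 `CN(C(=O)NC(=O)c1ccccc1F)c1nc(C(F)(F)F)c(C(=O)N/N=C/c2ccc(C(F)(F)F)cc2)s1`: 4.98 ug/mL
compound 2 `CN(C(=O)NC(=O)c1ccc([N+](=O)[O-])cc1)c1nc(C(F)(F)F)c(C(=O)N/N=C/c2cccc(C(F)(F)F)c2)s1`: 4.39 ug/mL

In a functional assay on MCF7 cells (Homo sapiens) for inhibition, read by MTT assay, with a stated time of 72 h (on this read-out lower numbers stand for stronger inhibition and higher numbers for weaker inhibition), compound 1 gives 4.98 ug/mL, and compound 2 gives 4.39 ug/mL. These two numbers lie within the usual scatter of each other, so compound 2 does not stand apart from compound 1. Compound 3 `CN(C(=O)NC(=O)c1ccc([N+](=O)[O-])cc1)c1nc(C(F)(F)F)c(C(=O)N/N=C/c2ccc([N+](=O)[O-])cc2)s1` differs from compound 2 in one place: 4-nitrophenyl in place of 3-(trifluoromethyl)phenyl on a carbon with a double bond to nitrogen. Among the measured compounds shown here, no measured pair shows what this change does, so in this assay the step is expected to be small, in no sure direction, and probably not beyond the scatter. The expected step is a 1.0-fold higher number from compound 2 to compound 3 (0.01 log units; within the scatter). Compound 3 is estimated at 4.5 ug/mL, with a range from 2 ug/mL to 10 ug/mL.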

Compound 3, half-maximal inhibitory concentration: 9.24 ug/mL
The estimate for compound 3 lay 2.1-fold (0.31 log units) below the measured number; low and high end bracket the measured number.
By their numbers in this assay, from the lowest: compounds 2, 1 and 3 (each within the scatter of the next, the first and the last beyond it).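

In this assay putting 4-nitrophenyl in place of 3-(trifluoromethyl)phenyl on a carbon with a double bond to nitrogen gives a 2.1-fold higher number from compound 2 to compound 3 (0.32 log units; beyond the scatter) and so a modest loss of inhibition. Among the compounds shown here, this is the first direct sign that the aryl group at this position can change the read-out beyond the scatter, although a single pair cannot show a general trend. Going by these compounds, how an amine, a carboxylic acid or a longer chain would fare at this position remains open. Nothing measured here explains the step.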